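Swapping an amide for a tetrazole: solubility of compound 3

The source may report more compounds than this note shows. Statements on the series, on what has been measured and on what is new or still open speak of the compounds shown alone.

Values so far in a physicochemical assay for solubility, with a stated time of 12 h, at pH 6.8, tested at 10 mM; on this read-out higher numbers stand for higher solubility and lower numbers for lower solubility
- compound 1 `COC(=O)c1ccc(CNC(=O)c2ccc(Cl)s2)c(NC(=O)c2nc3c(s2)CN(C)CC3)c1` gives 52 ug/mL
- compound 2 `CNC(=O)c1ccc(CNC(=O)c2ccc(Cl)s2)c(NC(=O)c2nc3c(s2)CN(C)CC3)c1` gives 2.7 ug/mL

Compound 2 holds the lower of the two numbers. Compound 3 `CN1CCc2nc(C(=O)Nc3cc(-c4nnn[nH]4)ccc3CNC(=O)c3ccc(Cl)s3)sc2C1` carries 1H-tetrazol-5-yl in place of methylcarbamoyl on an aromatic carbon of the same molecule. Among the measured compounds shown here, only one measured step bears on this: a 19-fold lower number from compound 1 to compound 2 (1.28 log units; beyond the scatter) is large and beyond the scatter, and it ends on that same methylcarbamoyl group. A single step cannot settle direction, but a sizeable upward move is expected, an estimated 9.3-fold higher number from compound 2 to compound 3 (0.97 log units; beyond the scatter) in this assay here. For compound 3 the estimated value is 25 ug/mL with an expected range from 4 ug/mL to 150 ug/mL in this test.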

Compound 3, solubility: 470 ug/mL
The estimate for compound 3 lay 19-fold (1.27 log units) below the measured number; measured number outside the range, above it.
By their numbers in this assay, from the lowest: compound 2; then compound 1; then compound 3.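

In this assay, this position on the aromatic ring responds strongly to the group it carries: 1H-tetrazol-5-yl in place of methylcarbamoyl gives a 170-fold higher number from compound 2 to compound 3 (2.24 log units; beyond the scatter), and in place of methoxycarbonyl it gives a 9.0-fold higher number from compound 1 to compound 3 (0.96 log units; beyond the scatter). The earlier compounds shown here showed only a drop between two carbonyl-bearing groups, whereas 1H-tetrazol-5-yl stands above both. Nothing measured here explains the size of these rises. On these data alone, whether a carboxylic acid or an amine at the same position would reach the number of compound 3 remains open.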